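Demethylation on the core: from compound 2 to compound 3

The compounds below may be only part of what the source reports. "The series", "measured", "known", "first", "only" and "open" are said of these compounds alone.

Measured so far:
- Compound 1, `COc1cc2oc(-c3cccc(NC(=O)c4ccc(C)cc4)c3)cc(=O)c2c(OC)c1OC`, gives 50.8% in a functional assay on UACC-62 cells (Homo sapiens) for inhibition, read by sulforhodamine B assay, tested at 10 uM; on this read-out higher numbers stand for more inhibition at the one concentration tested (going by the name of the read-out) and lower numbers for less inhibition.
- Compound 2, `COc1cc2oc(-c3cccc(C(=O)Nc4ccc(Cl)cc4)c3)cc(=O)c2c(OC)c1OC`, gives 107% in this assay.

For the measured compounds named here, compound 2 stands highest of the two numbers; the only measured step, a number 56.2 percentage points higher from compound 1 to compound 2 (beyond the scatter), separates it from compound 1 and lies beyond the scatter. That step changes the group on the middle ring, not the shared core.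

Compound 3, `COc1cc2oc(-c3cccc(C(=O)Nc4ccc(Cl)cc4)c3)cc(=O)c2c(O)c1OC`, keeps the whole of compound 2 except for one spot on the core: hydrogen in place of methyl on an oxygen on an aromatic ring. Going by the values given here, no measured pair shows this kind of change, so the step from compound 1 to compound 2 does not bear on it directly; it only shows that the shared core with the chlorophenyl amide arm gives the higher of the two numbers at the tested concentration. With no guide for the change itself, the expected step of a number 15 percentage points lower from compound 2 to compound 3 (beyond the scatter) from compound 2 to compound 3 is small, roughly within the scatter, leaning slightly downward. Compound 3 is therefore estimated at 92%, with a range from 60% to 112%.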

Compound 3, a percentage reported as inhibition, at one concentration (the size of the read-out at that concentration, not a potency): 57.3%
Estimate against measurement, compound 3: 34.7 percentage points above; the measured number lies below the stated range.
By their numbers in this assay, from the lowest: compounds 1 and 3 (each within the scatter of the next); then compound 2.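

Removing a single methyl, one carbon atom, from an oxygen on an aromatic ring of the core is enough to shift the result: in this assay, changing methoxy to hydroxy at this position gives a number 49.7 percentage points lower from compound 2 to compound 3 (beyond the scatter). The earlier step involved the amide arm, whereas this one shows that the core itself can also produce a large change in the number, even with the arm of compound 2 left untouched. Nothing available here explains why this small change has such a large effect, so the result stands as an observation without a known cause.

The compounds shown leave open whether an ethyl group on this oxygen, giving an ethoxy group, or an amine in place of the methoxy group would keep the number high, and whether the other methoxy groups on the core respond in the same way to the same change. For the compounds shown here, this change is also seen only with the arm of compound 2, so its size with the arm of compound 1 remains an open question.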